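The compounds below may be only part of what the source reports. "The series", "measured", "known", "first", "only" and "open" are said of these compounds alone.

Measured so far:
- compound 1 `O=C1c2cc(COc3ccccc3)nn2CCN1c1ccccc1F`, which gives 86% in a functional assay on HEK293 cells for positive allosteric modulation of metabotropic glutamate receptor 5 (Homo sapiens), read by calcium flux; on this read-out higher numbers stand for larger maximal responses and lower numbers for smaller maximal responses
- compound 2 `O=C1c2cc(COc3ccccc3)nn2CCN1c1cccc(F)c1`, which gives 81% in this assay
- compound 3 `O=C1c2cc(COc3ccccc3)nn2CCN1c1ccc(F)cc1F`, which gives 101% in this assay

All three share one core and differ only in the ring carried on the amide-type nitrogen. Compound 3 stands highest of the three: the step of a number 15 percentage points higher from compound 1 to compound 3 (beyond the scatter) and the step of a number 20 percentage points higher from compound 2 to compound 3 (beyond the scatter) both lie beyond the scatter, while the step of a number 5 percentage points lower from compound 1 to compound 2 (within the scatter) does not.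

Compound 4 `Cc1ccc(N2CCn3nc(COc4ccccc4)cc3C2=O)cc1` has not yet been measured. Its change from compound 3 is 4-methylphenyl in place of 2,4-difluorophenyl on an amide-type nitrogen in a ring. Going by the values given here, two measured steps bear on it. The step of a number 15 percentage points higher from compound 1 to compound 3 (beyond the scatter) and the step of a number 20 percentage points higher from compound 2 to compound 3 (beyond the scatter) show that adding fluorine to this ring raised the maximal response modestly, and the step of a number 5 percentage points lower from compound 1 to compound 2 (within the scatter) shows that moving a single fluoro changed little. Among the compounds with values here, no measured compound carries a methyl on this ring, so direct guidance for the entering group is lacking. Since both fluorines leave, a modest downward step is expected in this assay, estimated as a number 16 percentage points lower from compound 3 to compound 4 (beyond the scatter), bringing compound 4 back toward the level of compound 1 and compound 2. Compound 4 is therefore estimated at 85%, with a range from 65% to 105%.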

Compound 4, largest response reached (Emax), in percent of the reference or control that the assay uses: 65%
Estimate against measurement, compound 4: 20 percentage points above, within the range that was stated.
By their numbers in this assay, from the lowest: compound 4; then compounds 2 and 1 (each within the scatter of the next); then compound 3.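

The ring on the amide-type nitrogen can take the response well below the level of the fluorinated compounds in this assay: swapping in 4-methylphenyl gives a number 36 percentage points lower from compound 3 to compound 4 (beyond the scatter), a large step, along with a number 16 percentage points lower from compound 2 to compound 4 (beyond the scatter) and a number 21 percentage points lower from compound 1 to compound 4 (beyond the scatter), both modest. Going by these compounds alone, the earlier compounds showed only fluoro changes on this ring, so this is the first sign that a ring with a different kind of group can fall clearly below all three, which makes the maximal response more sensitive to this position than the single-fluoro pair alone suggested. No measured information explains why the 4-methylphenyl ring gives the lowest number of the four.

Compound 4 differs from the other three both in losing fluoro and in gaining methyl, so the two changes remain tangled; an unsubstituted phenyl ring and a 4-fluorophenyl ring would help pull them apart. Also open, as far as these compounds go, is whether other groups at that spot on the ring, such as chloro or methoxy, would follow compound 4 or compound 3.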